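Replacing the chain-end bromine of compound 3

The source may hold more compounds than are shown below. What is called first, only, known or untested is meant among the compounds shown, and "the series" means these compounds.

Among the compounds with values here, compound 3 `COc1ccc(N(C)c2ccnc(Cl)n2)cc1OCCBr` gives 5670 nM in a functional assay on HCT-116 cells (Homo sapiens) for antiproliferative activity, read by MTT assay, with a stated time of 48 h (a higher number here means a weaker inhibitor, a lower number a stronger inhibitor), the highest of the three numbers measured so far. Compound 1 `COc1ccc(N(C)c2ccnc(Cl)n2)cc1` gives 1460 nM and compound 2 `COc1ccc(N(C)c2ccnc(Cl)n2)cc1Cl` gives 1170 nM. The steps of a 3.9-fold higher number from compound 1 to compound 3 (0.59 log units; beyond the scatter) and a 4.8-fold higher number from compound 2 to compound 3 (0.69 log units; beyond the scatter) show that introducing the 2-bromoethoxy chain weakened inhibition, whereas a 1.2-fold lower number from compound 1 to compound 2 (0.10 log units; within the scatter) stays within the scatter. Compound 4 `COc1ccc(N(C)c2ccnc(Cl)n2)cc1OCCC[Se]C#N` keeps that chain and alters only its end: a group of 4 heavy atoms (2 carbon, 1 nitrogen, 1 selenium; no ring) in place of one bromine atom, on a saturated chain carbon, two bonds along the chain from an oxygen on an aromatic ring. Within the data shown here, no measured step changes the chain terminus, so the two chain-introducing steps fix the starting point but give no direction for this particular change. Compound 4 is therefore expected to stay close to its parent, with a 1.1-fold lower number from compound 3 to compound 4 (0.05 log units; within the scatter) not beyond the scatter. The estimate for compound 4 is 5000 nM, with a range from 1800 nM to 14000 nM.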

Compound 4, half-maximal inhibitory concentration: 3920 nM
The estimate for compound 4 lay 1.3-fold (0.11 log units) above the measured number; the measured number falls inside the stated range.
By their numbers in this assay, from the lowest: compounds 2 and 1 (each within the scatter of the next); then compounds 4 and 3 (each within the scatter of the next).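

In this assay, the selenium-containing group at the chain end takes the place of bromo with a 1.4-fold lower number from compound 3 to compound 4 (0.16 log units; within the scatter), so this chain end tolerates the change. The chain-bearing compound 4 still sits beyond the scatter from both chain-free compounds, with a 2.7-fold higher number from compound 1 to compound 4 (0.43 log units; beyond the scatter) and a 3.4-fold higher number from compound 2 to compound 4 (0.53 log units; beyond the scatter), so the new terminus does not undo the loss. Nothing available gives a cause for these steps. On these data alone, whether an amine or a carboxylic acid at the chain end, or a longer chain, would move the number away from that of compound 3 remains open.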